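This account rests on a few compounds, and the source may have more. Where it says the series, first, only, none or still open, it means among the compounds named here.

Measured compounds:
- Compound 1, `COc1ccc(N/C(CCNC2=CC(=O)c3ccccc3C2=O)=N\S(=O)(=O)c2ccc(C)cc2)cc1`: 6030 nM
- Compound 2, `Cc1ccc(S(=O)(=O)/N=C(/CCNC2=CC(=O)c3ccccc3C2=O)Nc2ccccc2[N+](=O)[O-])cc1`: 3090 nM
- Compound 3, `Cc1ccc(S(=O)(=O)/N=C(/CCNC2=CC(=O)c3ccccc3C2=O)Nc2cccc(C(F)(F)F)c2)cc1`: 89100 nM

All three share one core and differ only in the aryl group on the amine nitrogen. In a functional assay on MCF7 cells (Homo sapiens) for cytotoxicity, read by MTT assay, with a stated time of 48 h (a lower number here means a stronger inhibitor, a higher number a weaker inhibitor), compound 3 stands highest of the three numbers, that is, it is the weakest inhibitor; the step of a 15-fold higher number from compound 1 to compound 3 (1.17 log units; beyond the scatter) and the step of a 29-fold higher number from compound 2 to compound 3 (1.46 log units; beyond the scatter) are both large and beyond the scatter, while a 2.0-fold lower number from compound 1 to compound 2 (0.29 log units; within the scatter) lies within it.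

Compound 4, `Cc1ccc(S(=O)(=O)/N=C(/CCNC2=CC(=O)c3ccccc3C2=O)Nc2ccc(Cl)cc2Cl)cc1`, has not yet been measured. The change from compound 3 is 2,4-dichlorophenyl in place of 3-(trifluoromethyl)phenyl on an amine nitrogen. Among the compounds with values here, no measured step exchanges one halogen-bearing aryl group for another, so nothing directly parallels this move. What the data do show is that compound 3 is the outlier: the two other aryl groups, in compound 1 with 6030 nM and compound 2 with 3090 nM, sit far lower. A fourth aryl group therefore seems more likely to land nearer those two than to stay at the level of compound 3, though the width of that guess is considerable.

For compound 4 in this assay the estimate is 12000 nM, with a range from 2500 nM to 70000 nM, meaning an expected step of a 7.4-fold lower number from compound 3 to compound 4 (0.87 log units; beyond the scatter).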

Compound 4, half-maximal inhibitory concentration: 17000 nM
Compound 4: the middle estimate sits 1.4-fold (0.15 log units) below what was measured; low and high end bracket the measured number.
By their numbers in this assay, from the lowest: compounds 2 and 1 (each within the scatter of the next); then compound 4; then compound 3.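

In this assay, 2,4-dichlorophenyl on the amine nitrogen gives a 5.2-fold lower number from compound 3 to compound 4 (0.72 log units; beyond the scatter), so a second aryl group carrying halogen atoms does not share the high number seen with 3-(trifluoromethyl)phenyl, and compound 3 remains alone at the top of the series. Within the data shown here, the new group does not reach the lowest numbers either: a 5.5-fold higher number from compound 2 to compound 4 (0.74 log units; beyond the scatter) and a 2.8-fold higher number from compound 1 to compound 4 (0.45 log units; beyond the scatter) are both beyond the scatter, which places compound 4 at an intermediate level that the earlier compounds did not occupy. Nothing available explains why these aryl groups fall in this order.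

Each aryl group here differs from the others both in which substituents it carries and in where they sit, so the compounds shown cannot separate these two kinds of change. A plain phenyl group would give a reference point for the substituted rings, and a phenyl group with a single chlorine would show whether one chlorine is enough to give a number like that of compound 4.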